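The compounds below may be only part of what the source reports. "The series", "measured", "known", "first", "only" and "open" are said of these compounds alone.

Of the compounds shown here, three have been tested in an ADME assay on J744 cells (Mus musculus) for cytotoxicity, read by MTT assay, with a stated time of 48 h; a lower number here means a stronger inhibitor, a higher number a weaker inhibitor. Compound 1 `Cc1c(/C=N/NC(=O)c2cnn(-c3ccccc3)c2)no[n+]1[O-]` gives 295000 nM, and compound 3 `Cc1c(C(=O)N/N=C/c2ccccc2O)no[n+]1[O-]` gives 246000 nM. Going by the values given here, compound 2 `O=C(N/N=C/c1ccc2no[n+]([O-])c2c1)c1cccnc1` stands lowest of the three: in this assay compound 2 gives 31000 nM, a reading that lies beyond the scatter from both compound 3 and compound 1, so compound 2 is the strongest inhibitor among the three measured so far.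

Compound 4 `Cc1[nH]cnc1C(=O)N/N=C/c1ccc2no[n+]([O-])c2c1` has not yet been measured. It differs from compound 2 in one place: 5-methyl-1H-imidazol-4-yl in place of pyridin-3-yl on a carbonyl carbon. Among the compounds with values here, no pair among the measured compounds shows this same exchange, so the size of the step has to be judged without a direct precedent. The change keeps the group attached to the carbonyl carbon of the same size and leaves the rest of compound 2 untouched, so only a small shift is expected, with no clear direction that the available numbers could support; if anything, a slight drift toward a higher number is anticipated.

For compound 4 the expected reading in this assay is 45000 nM, with a range from 15000 nM to 150000 nM, which corresponds to a step of a 1.5-fold higher number from compound 2 to compound 4 (0.16 log units; within the scatter) that is expected to stay within or close to the scatter.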

Compound 4, half-maximal inhibitory concentration: 38000 nM
Beside the measured number, compound 4's estimate is 1.2-fold (0.07 log units) above it; the measured number falls inside the stated range.
By their numbers in this assay, from the lowest: compounds 2 and 4 (each within the scatter of the next); then compounds 3 and 1 (each within the scatter of the next).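

In this assay the exchange of pyridin-3-yl for 5-methyl-1H-imidazol-4-yl on a carbonyl carbon gives a 1.2-fold higher number from compound 2 to compound 4 (0.09 log units; within the scatter) and is the only single-place comparison among the compounds shown. It indicates that, at this place and on this core, a six-membered aromatic ring with 1 hetero atom can give way to a five-membered aromatic ring with 2 hetero atoms, with 1 hydrogen-bond donor gained, and the reading stays within the scatter, although both groups hold 6 heavy atoms, so the step says nothing about a change in size here. No measurement on hand bears on the cause of this result.

Going by these compounds, it remains open whether the reading would also hold with a group of another kind on this carbonyl carbon, such as an aliphatic amine, a carboxylic acid or a longer alkyl chain, and whether the methyl of the 5-methyl-1H-imidazol-4-yl group contributes anything. On these data alone, it is equally open whether the same exchange would give a comparable step on the core of compound 1 or compound 3.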